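The compounds below may be only part of what the source reports. "The series", "measured", "known", "first", "only" and "open" are said of these compounds alone.

In a functional assay on NCI-H460 cells (Homo sapiens) for cytotoxicity, read by MTT assay, with a stated time of 72 h (a higher number here means a weaker inhibitor, a lower number a stronger inhibitor), three compounds have been measured. Compound 1 (`CCN(CC)Cc1ccc2nc(NC(=O)N/N=C/c3cn(Cc4cccc(Cl)c4)c4ccccc34)sc2c1`) gives 220 nM, compound 2 (`CN(C)Cc1ccc2nc(NC(=O)N/N=C/c3c[nH]c4ccccc34)sc2c1`) gives 2550 nM, and compound 3 (`CCN(CC)Cc1ccc2nc(NC(=O)N/N=C/c3c[nH]c4ccccc34)sc2c1`) gives 3140 nM. Compound 2 thus stands with compound 3 at the high end of these numbers, the two lying within the scatter of each other and far from compound 1.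

Compound 4 (`CN(C)Cc1ccc2nc(NC(=O)N/N=C/c3cn(Cc4cccc(Cl)c4)c4ccccc34)sc2c1`) differs from compound 2 in one place: 3-chlorobenzyl in place of hydrogen on an aromatic nitrogen. In words, 3-chlorobenzyl takes the place of hydrogen on an aromatic nitrogen. The reverse of this exchange has been measured on the diethylamino compounds, where removing the 3-chlorobenzyl gives a 14-fold higher number from compound 1 to compound 3 (1.15 log units; beyond the scatter), a large step beyond the scatter. The change from dimethylamino to diethylamino gives a 1.2-fold higher number from compound 2 to compound 3 (0.09 log units; within the scatter), which lies within the scatter. The diethylamino result should therefore carry over to the dimethylamino pair, and a large step towards a lower number is expected. The expected step is a 13-fold lower number from compound 2 to compound 4 (1.11 log units; beyond the scatter). The estimated value for compound 4 is 200 nM, with an expected range from 80 nM to 500 nM.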

Compound 4, half-maximal inhibitory concentration: 420 nM
Compound 4: middle estimate off by 2.1-fold (0.32 log units), on the low side; the measured number falls inside the stated range.
By their numbers in this assay, from the lowest: compounds 1 and 4 (each within the scatter of the next); then compounds 2 and 3 (each within the scatter of the next).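

In this assay, 3-chlorobenzyl on the aromatic nitrogen also lowers the number on the dimethylamino core, a 6.1-fold lower number from compound 2 to compound 4 (0.78 log units; beyond the scatter), so the effect is now seen on two cores; the step is modest rather than large, but the two steps do not differ beyond the scatter: the same change on two cores in this assay, a 14-fold higher number (1.15 log units; beyond the scatter) from compound 1 to compound 3 and a 6.1-fold higher number (0.78 log units; beyond the scatter) from compound 4 to compound 2, 2.4-fold (0.37 log units) apart, within the scatter of two such steps
The exchange of diethylamino for dimethylamino, a 1.9-fold higher number from compound 1 to compound 4 (0.28 log units; within the scatter), stays within the scatter with 3-chlorobenzyl present, as it does with hydrogen there: the same change on two cores in this assay, a 1.2-fold higher number (0.09 log units; within the scatter) from compound 2 to compound 3 and a 1.9-fold lower number (0.28 log units; within the scatter) from compound 4 to compound 1, 2.4-fold (0.37 log units) apart, within the scatter of two such steps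
Across these four compounds, the group on the aromatic nitrogen therefore tracks the clear differences in the numbers while the amine does not, and none of the four goes against this.

On these data alone, what a plain benzyl or a methyl on that nitrogen would give remains open, so the contributions of the chlorine and the benzyl group cannot be separated. Also open, as far as these compounds go, is whether a morpholine in place of these two amines would leave the number as little changed.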